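Replacing the Amide Group on a Shared Core: Compound 4

This account rests on a few compounds, and the source may have more. Where it says the series, first, only, none or still open, it means among the compounds named here.

The compounds measured so far, with their values:

Compound 1, `CC(C)(C)C(=O)N1CCCn2nc(COc3ccccc3)cc21`, gives 64% in a functional assay on HEK293 cells for positive allosteric modulation of metabotropic glutamate receptor 5 (Homo sapiens), read by calcium flux; a higher number here means a larger maximal response, a lower number a smaller maximal response.
Compound 2, `O=C(C1CC1)N1CCCn2nc(COc3ccccc3)cc21`, gives 61% in this assay.
Compound 3, `O=C(c1ccc(F)cc1)N1CCCn2nc(COc3ccccc3)cc21`, gives 63% in this assay.

Compound 3 stands second highest of the three numbers, yet its nearest neighbour is compound 1, a number a number 1 percentage points lower from compound 1 to compound 3 (within the scatter), and its furthest is compound 2, a number a number 2 percentage points higher from compound 2 to compound 3 (within the scatter). Both gaps lie within the scatter, so the three compounds cannot be ranked against one another. The same holds for the step of a number 3 percentage points lower from compound 1 to compound 2 (within the scatter). All three steps change only the group on the carbonyl carbon, and none of them moved the largest response beyond the scatter.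

Compound 4, `O=C(c1ccno1)N1CCCn2nc(COc3ccccc3)cc21`, continues this series at the same position. The change from compound 3 is 1,2-oxazol-5-yl in place of 4-fluorophenyl on a carbonyl carbon. Every measured step at this position bears on it, and all were within the scatter, whether the group entering was a branched alkyl, a small ring or a six-membered aromatic ring. Within the data shown here, no measured pair shows how a five-membered aromatic ring with two hetero atoms behaves here, so the expectation rests on the flatness seen so far.

Compound 4 is therefore expected to give 62% in this assay, with a range from 50% to 74%. That estimate means a step of a number 1 percentage points lower from compound 3 to compound 4 (within the scatter), expected to stay within the scatter.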

Compound 4, largest response reached (reported as percent of maximum), in percent of the reference or control that the assay uses: 22%
Estimate against measurement, compound 4: 40 percentage points above; measured number outside the range, below it.
By their numbers in this assay, from the lowest: compound 4; then compounds 2, 3 and 1 (each within the scatter of the next).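

The group on the carbonyl carbon, which had made no difference beyond the scatter among tert-butyl, cyclopropyl and 4-fluorophenyl, does matter: in this assay 1,2-oxazol-5-yl gives a number 41 percentage points lower from compound 3 to compound 4 (beyond the scatter) and steps of similar size appear against the other two groups, with a number 39 percentage points lower from compound 2 to compound 4 (beyond the scatter) and with a number 42 percentage points lower from compound 1 to compound 4 (beyond the scatter) in the same read-out. The flatness of the first three compounds therefore holds for those groups only and does not extend to every group at this position, and compound 4 stands alone in the series. Compared with 4-fluorophenyl, the entering group is a five-membered aromatic ring with 2 hetero atoms and has 2 hydrogen-bond acceptors rather than none, but no measurement at hand explains why the response falls.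

The compounds shown leave open whether the loss follows the ring size or the hetero atoms, as these change together in this one step. A furan-2-yl or a pyridin-2-yl group on the same carbonyl carbon would bear on that question, and so would a 1,2-oxazol-3-yl group.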